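A few compounds are considered here, and "the series" means these few. Any claim that something is new, unique, unknown or untested is made for them only; others in the source may bear on it.

Three members of the series have been run in a functional assay on a cell-free system (plasma, Oryctolagus cuniculus) for inhibition of platelet-activating factor acetylhydrolase (Homo sapiens), tested at 100 nM; on this read-out lower numbers stand for less inhibition and higher numbers for more inhibition at the one concentration tested (going by the name of the read-out). Compound 1 `CCCCCCCCN(C)C(=O)Cn1cc(Cc2cnc(=O)n(CCO)c2)c(=O)nc1SCc1ccc(F)cc1` gives 36%. Among the measured compounds shown here, compound 2 `CCCCCCCCCCCCN(C)C(=O)Cn1cc(Cc2cnc(=O)n(CCO)c2)c(=O)nc1SCc1ccc(F)cc1` gives 36%; the only change is butyl in place of hydrogen on a saturated chain carbon, eight bonds along the chain from an amide-type nitrogen, and the step reads no change at the digits printed from compound 1 to compound 2 (within the scatter). Compound 3 `CCCCCCCCN(C)C(=O)Cn1cc(Cc2cnc(=O)n(CC(=O)NC)c2)c(=O)nc1SCc1ccc(F)cc1` gives 42%; its core differs from that of compound 1 by methylcarbamoyl in place of hydroxymethyl on a saturated chain carbon bound to an aromatic nitrogen, a step of a number 6 percentage points higher from compound 1 to compound 3 (within the scatter). Compound 4 `CCCCCCCCCCCCN(C)C(=O)Cn1cc(Cc2cnc(=O)n(CC(=O)NC)c2)c(=O)nc1SCc1ccc(F)cc1` has not been measured. It differs from compound 3 by butyl in place of hydrogen on a saturated chain carbon, eight bonds along the chain from an amide-type nitrogen, the same change in the same place as from compound 1 to compound 2, made twice in all among these compounds. For compound 4 the step is expected to be no change at the digits printed from compound 3 to compound 4 (within the scatter), set beside the earlier one, because no change at the digits printed from compound 1 to compound 2 (within the scatter) and the place of the change is the same word for word. Compound 4 is therefore estimated at 42%, with a range from 30% to 54%.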

Compound 4, a percentage reported as inhibition, at one concentration (the size of the read-out at that concentration, not a potency): 28%
Compound 4: the middle estimate sits 14 percentage points above what was measured, outside the stated range (below it).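

In this assay the butyl change gives a number 14 percentage points lower from compound 3 to compound 4 (beyond the scatter), yet this step cannot be separated from the earlier one on the core of compound 1: the same change on two cores in this assay, no change at the digits printed (within the scatter) from compound 1 to compound 2 and a number 14 percentage points lower (beyond the scatter) from compound 3 to compound 4, 14 percentage points apart, within the scatter of two such steps. The methylcarbamoyl change, read with the butyl-extended chain in place, gives a number 8 percentage points lower from compound 2 to compound 4 (within the scatter), and it also cannot be separated from its earlier step: the same change on two cores in this assay, a number 6 percentage points higher (within the scatter) from compound 1 to compound 3 and a number 8 percentage points lower (within the scatter) from compound 2 to compound 4, 14 percentage points apart, within the scatter of two such steps. These two pairs therefore do not show that either change depends on the core, nor do they establish that either carries over unchanged.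

The compounds shown leave open how a decyl chain would read on either core. They also leave open whether a carboxylic acid in place of the methylcarbamoyl group would keep the reading of compound 3.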